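Extending the acid-bearing chain on the aromatic nitrogen

The source may hold more compounds than are shown below. What is called first, only, known or untested is meant among the compounds shown, and "the series" means these compounds.

Measured compounds:
compound 1 `Cc1c(Cl)cccc1CCCCOc1ccc(C#Cc2cccc3c(CCCC(=O)O)c(C)n(CC(=O)O)c23)cc1` gives 3.2 10^-6 cm/s
compound 2 `Cc1c(CCCC(=O)O)c2cccc(/C=C/c3ccc(OCCCCc4c(F)c(F)cc(F)c4F)cc3)c2n1CC(=O)O` gives 0.5 10^-6 cm/s

Of the compounds shown here, two have been measured in a physicochemical assay for permeability, using PAMPA, with a stated time of 4 h, at pH 7.4, tested at 50 uM; on this read-out lower numbers stand for lower permeability and higher numbers for higher permeability. Compound 1 gives 3.2 10^-6 cm/s, the higher of the two numbers. Compound 2 gives 0.5 10^-6 cm/s, and the gap between these two lies beyond the scatter. Among the measured compounds shown here, the two compounds differ in several places at once, so no single-change step between them exists; their two values show only where each stands.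

Compound 3 `Cc1c(Cl)cccc1CCCCOc1ccc(C#Cc2cccc3c(CCCC(=O)O)c(C)n(CCC(=O)O)c23)cc1` differs from compound 1 in one place: carboxymethyl in place of carboxy on a saturated chain carbon bound to an aromatic nitrogen. For the measured compounds named here, no measured pair shows this change, so the expectation rests on compound 1 alone. The step of a 1.1-fold higher number from compound 1 to compound 3 (0.04 log units; within the scatter) is expected to be small, with no direction that would reach beyond the scatter. Compound 3 is accordingly estimated at 3.5 10^-6 cm/s, with a range from 1.5 10^-6 cm/s to 8 10^-6 cm/s in this assay.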

Compound 3, apparent permeability: 3 10^-6 cm/s
Beside the measured number, compound 3's estimate is 1.2-fold (0.07 log units) above it; the measured number falls inside the stated range.
By their numbers in this assay, from the lowest: compound 2; then compounds 3 and 1 (each within the scatter of the next).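

Read as carboxymethyl to 2-carboxyethyl on the aromatic nitrogen, this lengthening of the acid-bearing chain gives in this assay a 1.1-fold lower number from compound 1 to compound 3 (0.03 log units; within the scatter) as the first single-change step in the series. At this position, then, the longer chain leaves compound 3 within the scatter of compound 1, and the two cannot be told apart on this read-out. Nothing in the data offered here accounts for this result.

From the compounds shown here alone, whether a still longer chain such as 3-carboxypropyl, or a primary amide or an amine at the end of this chain, would carry the number beyond the scatter remains open. So does whether the same change would give a similarly small step on compound 2, whose value of 0.5 10^-6 cm/s lies in a different structural setting.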